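This account rests on a few compounds, and the source may have more. Where it says the series, first, only, none or still open, it means among the compounds named here.

Measured in an ADME assay on microsomes from liver (Homo sapiens) for metabolic stability, with a stated time of 30 min, tested at 1 uM; a lower number here means that the compound disappears faster, a higher number that the compound lasts longer:
- compound 1 `COc1ccc2[nH]c(C(=O)N3CC(=O)N(Cc4ccccc4)[C@@H](COc4ccccc4)C3)cc2c1`: 0.65 h
- compound 2 `O=C(c1cc2cc(C3CC3)ccc2[nH]1)N1CC(=O)N(Cc2ccccc2)[C@@H](CN2CCC(F)CC2)C1`: 0.383 h

Among the measured compounds shown here, only two numbers are available so far. Compound 1 at 0.65 h and compound 2 at 0.383 h lie within the usual scatter of repeated measurements, so these data do not rank them. The next compound to be tested is compound 3 `COc1ccc2[nH]c(C(=O)N3CC(=O)N(Cc4ccccc4)[C@@H](COC(C)(C)C)C3)cc2c1`. It keeps the core of compound 1 but carries tert-butyl in place of phenyl on an oxygen on a saturated carbon. For the measured compounds named here, no measured pair shows what this exchange does in this assay, so the expectation is cautious and stays close to compound 1 at 0.65 h. The expected 1.2-fold lower number from compound 1 to compound 3 (0.07 log units; within the scatter) is no larger than the scatter, in either direction. For compound 3 the estimated half-life is 0.55 h, with an expected range of 0.25 h to 1.2 h.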

Compound 3, half-life: 0.278 h
Beside the measured number, compound 3's estimate is 2.0-fold (0.30 log units) above it, and the stated range covers the measured number.
By their numbers in this assay, from the lowest: compounds 3, 2 and 1 (each within the scatter of the next, the first and the last beyond it).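

Among the compounds shown here, with the core of compound 1 held fixed, this pair gives the first reading of what the group on this oxygen does in this assay: tert-butyl in place of phenyl gives a 2.3-fold lower number from compound 1 to compound 3 (0.37 log units; beyond the scatter). The position is therefore not indifferent to its substituent, and this exchange of an aromatic ring for a branched group without a ring costs half-life, by a modest step. Nothing measured here explains why the number falls.

One pair cannot show whether the loss comes from removing phenyl or from adding tert-butyl, nor whether it would recur on another core. On these data alone, how a methyl, a cyclohexyl or a pyridine ring on this oxygen would compare also stays open, and a cyclohexyl would help to separate the effect of having a ring from that of being aromatic.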